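Swapping allyl for a hydroxypropenyl arm on a cytotoxicity readout

This account rests on a few compounds, and the source may have more. Where it says the series, first, only, none or still open, it means among the compounds named here.

Compound 1 `C=CCc1cc(OC)c(O[C@H](C)[C@H](OC(C)=O)c2cc(OC)c(OC)c(OC)c2)c(OC)c1` gives 85000 nM
Compound 2 `COc1cc(C(=O)[C@@H](C)Oc2c(OC)cc(/C=C/CO)cc2OC)cc(OC)c1OC` gives > 200000 nM

Of the compounds shown here, two have been measured in an ADME assay on P3HR-1 cells (Homo sapiens) for cytotoxicity, read by microscopy and trypan blue exclusion, with a stated time of 2 days; a higher number here means that more compound is tolerated, a lower number that less compound is tolerated. Within the data shown here, compound 1, with the structure `C=CCc1cc(OC)c(O[C@H](C)[C@H](OC(C)=O)c2cc(OC)c(OC)c(OC)c2)c(OC)c1`, gives the only outright number, 85000 nM. Compound 2, with the structure `COc1cc(C(=O)[C@@H](C)Oc2c(OC)cc(/C=C/CO)cc2OC)cc(OC)c1OC`, returns a limit of the assay rather than a number, namely > 200000 nM. This limit is the reference point among the values shown: the limit of > 200000 nM in this assay, at which 1 of the 2 values shown sits. Among the measured compounds shown here, no step between compound 1 and compound 2 has been worked out, so all that can be said is that compound 1 gives a number and compound 2 gives a limit.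

Compound 3 has the structure `COc1cc([C@@H](OC(C)=O)[C@@H](C)Oc2c(OC)cc(/C=C/CO)cc2OC)cc(OC)c1OC` and has not yet been tested. It differs from compound 1 by one change: 3-hydroxyprop-1-en-1-yl in place of allyl on an aromatic carbon. For the measured compounds named here, whether this change moves the half-maximal cytotoxic concentration cannot be read from the two measured compounds, since no measured step isolates it. The expectation is a modest move toward more compound being tolerated, possibly no larger than the usual scatter. The estimated step from compound 1 to compound 3 in this assay is a 1.8-fold higher number from compound 1 to compound 3 (0.25 log units; within the scatter). For compound 3 the expected value in this assay is 150000 nM, with a likely range from 60000 nM to 400000 nM.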

Compound 3, half-maximal cytotoxic concentration: > 200000 nM
Compound 3 was reported as a limit (the forecaster's own chance of this, stated with the estimate: 35%); middle value at least 1.3-fold (0.12 log units) from the limit.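

Among the compounds shown, the exchange of allyl for 3-hydroxyprop-1-en-1-yl on this aromatic carbon, meta to two methoxy groups, can now be read on its own in this assay, and it gives an at least 2.3-fold higher number from compound 1 to compound 3 (0.37 log units; beyond the scatter). Compound 3 gives > 200000 nM, which is a limit of the assay and not a number. The step is therefore a minimum that already lies beyond the scatter, and its full size stays unknown because the read-out ends at a limit: the limit of > 200000 nM in this assay, at which 2 of the 3 values shown sit.

Among the compounds shown, 3-hydroxyprop-1-en-1-yl is the only group set against allyl in a single-place comparison, so it remains open how a carboxylic acid, an amine or a longer chain ending in a hydroxyl would read on this aromatic carbon. Also open, from the compounds shown here alone, are how much more compound 3 would be tolerated past its limit, and whether the same exchange would give a similar step on a core other than that of compound 1.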